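This account rests on a few compounds, and the source may have more. Where it says the series, first, only, none or still open, it means among the compounds named here.

Working notes on the series. Compound 1 `C/C1=C\CC[C@@]2(C)O[C@@H]2[C@H]2OC(=O)[C@@H](CN3CCCCC3)[C@@H]2C[C@H]1O` and compound 2 `C/C1=C\CC[C@@]2(C)O[C@@H]2[C@H]2OC(=O)[C@@H](CN3CCN(c4ccccc4)CC3)[C@@H]2C[C@H]1O` share one core and differ in the amine it carries. In a functional assay on MCF7 cells (Homo sapiens) for inhibition, read by MTT assay, with a stated time of 72 h (a higher number here means a weaker inhibitor, a lower number a stronger inhibitor), compound 1 gives 16000 nM and compound 2 gives 19000 nM. These two values lie within the scatter of each other, so compound 2 stands level with compound 1 on the numbers available.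

Compound 3 `COc1ccc(N2CCN(C[C@@H]3C(=O)O[C@H]4[C@H]3C[C@@H](O)/C(C)=C/CC[C@@]3(C)O[C@H]43)CC2)cc1` departs from compound 2 by one change: methoxy in place of hydrogen on an aromatic carbon. In words, this is methoxy in place of hydrogen on an aromatic carbon, taking phenyl to 4-methoxyphenyl.

Among the compounds with values here, no two measured compounds differ in one place, so no measured step speaks directly to this change. Within the data shown here, the only guide is the pair already in hand: the amine differs between compound 1 at 16000 nM and compound 2 at 19000 nM, yet the values stay within the scatter. In this assay no step beyond the scatter is therefore expected, and no direction is favoured. The expected size is a 1.1-fold lower number from compound 2 to compound 3 (0.02 log units; within the scatter). For compound 3 the estimated value is 18000 nM. The expected range for that estimate runs from 9000 nM to 36000 nM.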

Compound 3, half-maximal inhibitory concentration: 24000 nM
Compound 3: the middle estimate sits 1.3-fold (0.12 log units) below what was measured, within the range that was stated.
By their numbers in this assay, from the lowest: compounds 1, 2 and 3 (each within the scatter of the next).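

In this assay, within the data shown here, methoxy in place of hydrogen on an aromatic carbon gives a 1.3-fold higher number from compound 2 to compound 3 (0.10 log units; within the scatter), the only step so far that reads a change in one place. It shows that taking phenyl to 4-methoxyphenyl, with the methoxy group para to a large group on the six-membered aromatic ring, leaves compound 3 level with compound 2, so this position accepts a group of 2 heavy atoms, including 1 hydrogen-bond acceptor, without a step beyond the scatter. Nothing at hand gives a reason for this result.

Still open, from the compounds shown here alone, is whether another group at this place, such as a chlorine atom, a carboxylic acid or a primary amine, would give a step beyond the scatter, and whether methoxy on a different carbon of the same ring would read as it does here. Also open is whether a morpholine or an open-chain dimethylamine on the shared core would give a number apart from those of the three compounds shown.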